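A few compounds are considered here, and "the series" means these few. Any claim that something is new, unique, unknown or untested is made for them only; others in the source may bear on it.

Measured so far:
compound 1 `N=C(NCc1ccc(O)cc1)[C@@H]1CCC(=O)N1Cc1ccccc1[N+](=O)[O-]`: 26.9%
compound 2 `COc1ccc(CNC(=N)[C@@H]2CCC(=O)N2Cc2ccccc2[N+](=O)[O-])cc1`: 21.1%
compound 3 `COc1ccc(CN2C(=O)CC[C@H]2C(=N)NCc2ccc(O)cc2)cc1`: 20.5%

All three were tested in a functional assay on SH-SY5Y cells (Homo sapiens) for cytotoxicity, read by MTT assay, with stated times of 8 h, 30 min and 12 h, tested at 0.5 uM; on this read-out lower numbers stand for a weaker effect and higher numbers for a stronger effect at the one concentration tested. From compound 1 to compound 2 the change is methyl in place of hydrogen on an oxygen on an aromatic ring, and the step is a number 5.8 percentage points lower from compound 1 to compound 2 (within the scatter). The cores of compound 1 and compound 3 differ by 4-methoxyphenyl in place of 2-nitrophenyl on a saturated chain carbon bound to an amide-type nitrogen in a ring, with a step of a number 6.4 percentage points lower from compound 1 to compound 3 (within the scatter). Compound 4 `COc1ccc(CNC(=N)[C@@H]2CCC(=O)N2Cc2ccc(OC)cc2)cc1` has not yet been measured in this assay. It differs from compound 3 by methyl in place of hydrogen on an oxygen on an aromatic ring, the same change as that from compound 1 to compound 2, at a place described in identical words. The step from compound 3 to compound 4 is therefore expected to resemble the earlier one, a number 5 percentage points lower from compound 3 to compound 4 (within the scatter), resting on the step of a number 5.8 percentage points lower from compound 1 to compound 2 (within the scatter) and on compound 3 at 20.5%. Compound 4 is estimated at 15.5%, between 5% and 27%.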

Compound 4, a percentage reported as activity, at one concentration (the size of the read-out at that concentration, not a potency): 24.8%
Compound 4: middle estimate off by 9.3 percentage points, on the low side; measured number inside the range.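

In this assay, hydroxy to methoxy gives a number 4.3 percentage points higher from compound 3 to compound 4 (within the scatter), and set beside the earlier step on the other core, it shows no real difference: the same change on two cores in this assay, a number 5.8 percentage points lower (within the scatter) from compound 1 to compound 2 and a number 4.3 percentage points higher (within the scatter) from compound 3 to compound 4, 10.1 percentage points apart, within the scatter of two such steps

The change to 4-methoxyphenyl in place of 2-nitrophenyl gives a number 3.7 percentage points higher from compound 2 to compound 4 (within the scatter), and it too reads alike on both cores: the same change on two cores in this assay, a number 6.4 percentage points lower (within the scatter) from compound 1 to compound 3 and a number 3.7 percentage points higher (within the scatter) from compound 2 to compound 4, 10.1 percentage points apart, within the scatter of two such steps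

Every step here lies within the scatter, which gives no sign that the core alters either change, but also does not show that either change has a real effect of its own to carry over.

The compounds shown leave open whether an amine or a carboxylic acid on the aromatic ring, in place of hydroxy or methoxy, would give a step clear of the scatter. They also leave open what a longer chain in place of the methyl would do.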